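Anilinoquinazoline vinyl sulfones: aryl halogen variation and MCF7 growth

The source may report more compounds than this note shows. Statements on the series, on what has been measured and on what is new or still open speak of the compounds shown alone.

Measured so far:
compound 1 `O=S(=O)(/C=C/c1ccccc1)Cc1ccc(Nc2ncnc3ccccc23)cc1` — 74000 nM
compound 2 `O=S(=O)(/C=C/c1ccc(F)cc1)Cc1ccc(Nc2ncnc3ccccc23)cc1` — 16000 nM
compound 3 `O=S(=O)(/C=C/c1ccc(Cl)cc1)Cc1ccc(Nc2ncnc3ccccc23)cc1` — 52000 nM

All three share the same core and differ only in the halogen on the styryl ring. In a functional assay on MCF7 cells (Homo sapiens) (a higher number here means a weaker inhibitor of growth, a lower number a stronger inhibitor of growth), compound 2 gives the lowest number of the three and is the strongest inhibitor of growth here: its steps to the others are a 4.6-fold lower number from compound 1 to compound 2 (0.67 log units; beyond the scatter) and, in the reverse direction, a 3.3-fold higher number from compound 2 to compound 3 (0.51 log units; beyond the scatter), both beyond the scatter. Compound 1 and compound 3 sit close together, a 1.4-fold lower number from compound 1 to compound 3 (0.15 log units; within the scatter) being within the scatter.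

Compound 4 `O=S(=O)(/C=C/c1ccc(Cl)cc1Cl)Cc1ccc(Nc2ncnc3ccccc23)cc1` has not been measured in this assay. Relative to compound 2 the change is 2,4-dichlorophenyl in place of 4-fluorophenyl on a double-bonded chain carbon bound to a double-bonded chain carbon. Going by the values given here, two measured steps bear on it. The replacement of fluoro by chloro alone gave a 3.3-fold higher number from compound 2 to compound 3 (0.51 log units; beyond the scatter), a modest loss; chloro in place of hydrogen gave a 1.4-fold lower number from compound 1 to compound 3 (0.15 log units; within the scatter), no real change. As far as these compounds go, nothing measured speaks to the second chloro, so its effect is unknown and the range must stay wide. The expected step is therefore a modest rise in the number, roughly a 2.8-fold higher number from compound 2 to compound 4 (0.45 log units; beyond the scatter), in line with compound 3.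

For compound 4 the estimate in this assay is 45000 nM, with a plausible range of 12000 nM to 160000 nM.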

Compound 4, concentration for 50% growth inhibition: 4000 nM
Compound 4: middle estimate off by 11-fold (1.05 log units), on the high side; measured number outside the range, below it.
By their numbers in this assay, from the lowest: compound 4; then compound 2; then compounds 3 and 1 (each within the scatter of the next).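

In this assay the chloro added to compound 3 gives a much larger step than the first chloro did: a 13-fold lower number from compound 3 to compound 4 (1.11 log units; beyond the scatter), against a 1.4-fold lower number from compound 1 to compound 3 (0.15 log units; within the scatter), so the step for chloro in place of hydrogen on this ring depends on which hydrogen is replaced and on what the ring already carries. The 2,4-dichlorophenyl group also displaces 4-fluorophenyl as the best group shown, with a 4.0-fold lower number from compound 2 to compound 4 (0.60 log units; beyond the scatter) and a 19-fold lower number from compound 1 to compound 4 (1.27 log units; beyond the scatter), which changes the order seen among phenyl and the two singly halogenated rings, where compound 2 had the lowest number. Nothing available accounts for the size of these steps.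

Whether the gain belongs to chloro itself or would also appear with another group at the same place stays open, since the compounds shown carry only fluoro and chloro on the styryl ring and leave bromo, methyl and methoxy untested as alternatives. Also open, as far as these compounds go, is whether a third ring substituent, or an amine on the ring to replace a chloro, would extend or lose the step seen with compound 4.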